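Configuration flip at the dioxane ring carbon

The source may report more compounds than this note shows. Statements on the series, on what has been measured and on what is new or still open speak of the compounds shown alone.

In an assay on Cerebral cortex (strain Sprague-Dawley) for displacement of a labelled ligand from Neuronal acetylcholine receptor; alpha4/beta2 (Rattus norvegicus) (on this read-out lower numbers stand for stronger inhibition and higher numbers for weaker inhibition), compound 3 `COc1ccc2c(c1)O[C@@H]([C@@H]1CCCN1C)CO2` gives 4200 nM, the second highest of the three numbers measured: compound 1 `CN1CCC[C@H]1[C@@H]1COc2ccc(CO)cc2O1` gives 51000 nM and compound 2 `CN1CCC[C@H]1[C@@H]1COc2ccc(O)cc2O1` gives 12 nM. Among the measured compounds shown here, the only measured step, a 4300-fold lower number from compound 1 to compound 2 (3.63 log units; beyond the scatter), concerns an exchange of groups on the aromatic ring, not configuration. Compound 4 `COc1ccc2c(c1)O[C@H]([C@@H]1CCCN1C)CO2` differs from compound 3 in configuration alone: the two compounds have the same atoms and bonds and differ only in configuration as drawn: 1 of 2 stereo elements differ; a stereocentre at a saturated ring carbon is drawn S in compound 3 and R in compound 4. For the measured compounds named here, no measured step bears on a change of configuration, so neither size nor direction can be read from the series; the working expectation is a number near that of compound 3 with a wide range. Compound 4 is therefore estimated at 4200 nM (range 400 nM to 40000 nM). The expected step is no change at the digits printed from compound 3 to compound 4 (within the scatter).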

Compound 4, inhibition constant: 17000 nM
Compound 4: the middle estimate sits 4.0-fold (0.61 log units) below what was measured, within the range that was stated.
By their numbers in this assay, from the lowest: compound 2; then compound 3; then compound 4; then compound 1.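

In this assay there is a 4.0-fold higher number from compound 3 to compound 4 (0.61 log units; beyond the scatter), so configuration at this saturated ring carbon does register, with the form drawn S giving the lower number. The shift can be assigned to that stereocentre alone: the fact that compounds 3 and 4 differ only in the configuration as drawn. On the aromatic ring, capping the hydroxy of compound 2 with methyl costs far more, with a 1400-fold higher number from compound 2 to compound 4 (3.15 log units; beyond the scatter), while methoxy and hydroxymethyl lie closer, with a 3.0-fold lower number from compound 1 to compound 4 (0.48 log units; beyond the scatter).

Going by these compounds, whether the configuration step keeps its size with hydroxy in place of methoxy remains open. So does the effect of an amine or a carboxylic acid at this aromatic carbon.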